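Changing the Aromatic Arm on the Core, Not the Amine

The compounds below may be only part of what the source reports. "The series", "measured", "known", "first", "only" and "open" are said of these compounds alone.

Compound 1 `COc1cccc(Oc2ccc3c(NCCCNCc4cc(F)ccc4OC)ccnc3c2)c1`, compound 2 `COc1cccc(Oc2ccc3c(NCCCNCc4ccco4)ccnc3c2)c1` and compound 3 `COc1cccc(Oc2ccc3c(NCCCNCc4cccc(OC)c4O)ccnc3c2)c1` share one core and differ only in the aromatic group on a saturated chain carbon bound to an amine nitrogen. In a physicochemical assay for acid dissociation, compound 1 gives 9.28, compound 2 gives 9.28 and compound 3 gives 9.28, so compound 3 stands level with both. The steps of no change at the digits printed from compound 1 to compound 2 (within the scatter), no change at the digits printed from compound 1 to compound 3 (within the scatter) and no change at the digits printed from compound 2 to compound 3 (within the scatter) confirm this. Compound 4 `COc1cccc(CNCCCNc2ccnc3cc(Cc4ccc(C#N)cc4)ccc23)c1O` alters a different site: 4-cyanobenzyl in place of 3-methoxyphenoxy on an aromatic carbon. For the measured compounds named here, no measured step touches that site, so none bears on it directly; the measured steps only show that exchanging an aromatic group on the saturated chain carbon left the read-out still. Compound 4 is therefore expected to shift by a number 0.03 log units lower from compound 3 to compound 4 (within the scatter), not beyond the scatter. Compound 4 is estimated at 9.25, between 8.85 and 9.65.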

Compound 4, acid dissociation constant: 9.47
Beside the measured number, compound 4's estimate is 0.22 log units below it; the range from low to high includes it.
By their numbers in this assay, from the lowest: compounds 1, 2, 3 and 4 (each within the scatter of the next).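

In this assay, putting 4-cyanobenzyl in place of 3-methoxyphenoxy on this aromatic carbon gives a number 0.19 log units higher from compound 3 to compound 4 (within the scatter). For the compounds shown here, this is the first measured change at this site, and like the earlier exchanges on the saturated chain carbon, it stays within the scatter. Nothing available explains why the read-out holds steady here. Still open, going by these compounds, is whether a carboxylic acid or an amine on this aromatic carbon would move the number beyond the scatter. A longer chain carrying the amine nitrogen also remains an open question.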